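Phenyl in Place of Pyridin-3-yl on the Carbonyl

The source may report more compounds than this note shows. Statements on the series, on what has been measured and on what is new or still open speak of the compounds shown alone.

Three compounds have been measured in a functional assay on A549 cells (Homo sapiens) for cytotoxicity, read by sulforhodamine B assay, with a stated time of 2 days, tested at 100 uM; on this read-out higher numbers stand for more inhibition at the one concentration tested (going by the name of the read-out) and lower numbers for less inhibition:

compound 1, `O=C(Nn1c(-c2cccc([N+](=O)[O-])c2)nc2c(-c3ccc(Cl)cc3)n[nH]c2c1=O)c1cccnc1`: 19.7%
compound 2, `O=C(Nn1c(-c2cccc([N+](=O)[O-])c2)nc2c(-c3ccco3)n[nH]c2c1=O)c1cccnc1`: 1.51%
compound 3, `COc1cccc(-c2nc3c(-c4ccco4)n[nH]c3c(=O)n2NC(=O)c2cccnc2)c1`: 14.9%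

Two single-point changes connect them. The step of a number 18.2 percentage points lower from compound 1 to compound 2 (beyond the scatter) goes with furan-2-yl in place of 4-chlorophenyl on an aromatic carbon. The step of a number 13.4 percentage points higher from compound 2 to compound 3 (beyond the scatter) goes with methoxy in place of nitro on an aromatic carbon. Among the three numbers compound 3 lies beyond the scatter above compound 2, while compound 3 and compound 1 sit within the scatter of each other, so no order between those two can be claimed.

Compound 4, `COc1cccc(-c2nc3c(-c4ccco4)n[nH]c3c(=O)n2NC(=O)c2ccccc2)c1`, differs from compound 3 only at the carbonyl carbon: phenyl in place of pyridin-3-yl on a carbonyl carbon. Neither measured step touches this part of the molecule; the step from compound 1 to compound 2 and the step from compound 2 to compound 3 both alter aromatic substituents elsewhere on the shared core, so the data give no direct guide to this exchange. With nothing shown to the contrary, compound 4 is expected to stay close to compound 3, with the step of a number 0.1 percentage points higher from compound 3 to compound 4 (within the scatter) expected to remain within the scatter. Compound 4 is therefore estimated at 15% in this assay, with a range from 2% to 30%.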

Compound 4, a percentage reported as inhibition, at one concentration (the size of the read-out at that concentration, not a potency): 53.8%
Beside the measured number, compound 4's estimate is 38.8 percentage points below it; the whole stated range lies below it.
By their numbers in this assay, from the lowest: compound 2; then compounds 3 and 1 (each within the scatter of the next); then compound 4.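

In this assay, the group on the carbonyl carbon proves to be far from a silent part of the molecule: phenyl in place of pyridin-3-yl gives a number 38.9 percentage points higher from compound 3 to compound 4 (beyond the scatter). This is the largest step in the series, exceeding both changes on aromatic carbons elsewhere on the shared core, a number 18.2 percentage points lower from compound 1 to compound 2 (beyond the scatter) and a number 13.4 percentage points higher from compound 2 to compound 3 (beyond the scatter), even though a six-membered aromatic ring of carbon only has simply taken the place of a six-membered aromatic ring with a nitrogen in it. Nothing measured here accounts for the size of this step, so it stands as an observation without an explanation.

The compounds shown leave open whether the same exchange would carry the same weight with other substituents on the shared core, since this single pair has the methoxy and furan-2-yl groups of compound 3, and a partner of compound 1 or compound 2 with phenyl on the carbonyl carbon would test this. They also leave open how the read-out responds to other groups at this place, such as pyridin-4-yl, cyclohexyl, or a phenyl ring carrying a carboxylic acid or an amine.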